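This account rests on a few compounds, and the source may have more. Where it says the series, first, only, none or still open, it means among the compounds named here.

Measured compounds:
- Compound 1, `CC(=O)c1ccc(N2CCN(CCCOc3ccc4c(c3)CCC4)CC2)cc1`: 13%
- Compound 2, `c1ccc(N2CCN(CCCOc3cccc4c3CCC4)CC2)cc1`: 0%

In a functional assay on the whole organism for inhibition, with Mus musculus as the target, at a dose of 25 mg/kg by the oral route (a higher number here means more inhibition at the dose given (going by the name of the read-out), a lower number less inhibition), compound 1 gives 13%, while compound 2 gives 0%. Compound 2 thus stands lowest of the two numbers recorded, and its nearest neighbour, compound 1, sits higher by a gap beyond the usual scatter. These two compounds differ in more than one place. Their pair tells nothing about the effect of any single change.

Compound 3, `Fc1ccc(N2CCN(CCCOc3cccc4c3CCC4)CC2)cc1`, has not yet been measured. It differs from compound 2 in one place: fluoro in place of hydrogen on an aromatic carbon. Within the data shown here, no measured step of this kind is available, so the expectation in this assay is a step from compound 2 to compound 3 of no size beyond the scatter, in either direction. The estimate for compound 3 is therefore 5%, with a range from 0% to 20%, meaning an expected step of a number 5 percentage points higher from compound 2 to compound 3 (within the scatter).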

Compound 3, a percentage reported as inhibition, in the whole organism at one dose (the size of the read-out at that dose, not a potency): 5%
Compound 3: middle estimate and measured number agree at the digits printed, and the stated range covers the measured number.
By their numbers in this assay, from the lowest: compounds 2, 3 and 1 (each within the scatter of the next, the first and the last beyond it).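

In this assay, among these compounds, fluoro in place of hydrogen on an aromatic carbon, para to a large group, gives a number 5 percentage points higher from compound 2 to compound 3 (within the scatter) and this is the first reading of a single change. At this position, phenyl to 4-fluorophenyl therefore moves the number by no more than repeated measurements of the same compound could, so this one change brings no clear gain in inhibition at the dose given. No measurement at hand explains this result or links it to any property of the fluorine atom.

Going by these compounds, it remains open whether another group on this same aromatic carbon, such as chloro, methoxy or a nitrile, would shift the number beyond the scatter. Also open, on these data alone, is what a longer chain within the shared core would do.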